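A few compounds are considered here, and "the series" means these few. Any claim that something is new, unique, unknown or untested is made for them only; others in the source may bear on it.

Measured in a functional assay on DU-145 cells (Homo sapiens) for inhibition, read by trypan blue exclusion, with a stated time of 96 h; a higher number here means a weaker inhibitor of growth, a lower number a stronger inhibitor of growth:
- Compound 1 `COc1cc(OC)c(/C=C(/SCc2ccc(Cl)cc2)C(=O)c2ccc([N+](=O)[O-])cc2)c(OC)c1`: > 100000 nM, a limit of the assay and not a number
- Compound 2 `COc1ccccc1/C=C(\C(=O)c1ccc([N+](=O)[O-])cc1)S(=O)(=O)Cc1ccc(Cl)cc1`: 10000 nM

For the measured compounds named here, compound 2, at 10000 nM, holds the only actual number so far. Compound 3 `COc1cc(OC)c(/C=C(\C(=O)c2ccc([N+](=O)[O-])cc2)S(=O)(=O)Cc2ccc(Cl)cc2)c(OC)c1` carries 2,4,6-trimethoxyphenyl in place of 2-methoxyphenyl on a double-bonded chain carbon bound to a double-bonded chain carbon. Going by the values given here, no measured pair shows what this change does, so any forecast is a judgement and its range must stay wide. A large move towards stronger growth inhibition in this assay is expected, well beyond the usual scatter, and the estimated step is a 20-fold lower number from compound 2 to compound 3 (1.30 log units; beyond the scatter). For compound 3 the estimated value is 500 nM, with an expected range of 30 nM to 8000 nM.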

Compound 3, concentration for 50% growth inhibition: 10000 nM
For compound 3 the middle estimate is 20-fold (1.30 log units) below the measured one, and the stated range ends below it.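

Putting 2,4,6-trimethoxyphenyl in place of 2-methoxyphenyl on this double-bonded chain carbon gives no change at the digits printed from compound 2 to compound 3 (within the scatter) in this assay, so the extra methoxy groups make no visible difference here. Putting (4-chlorobenzyl)sulfonyl in place of (4-chlorobenzyl)sulfanyl gives an at least 10-fold lower number from compound 1 to compound 3 (1.00 log units; beyond the scatter), so in this pair the change at the sulfur group does shift the number. The true size of that step stays unknown, since the value of compound 1 is a limit of the assay and not a number: the limit of > 100000 nM in this assay, at which 1 of the 3 values shown sits.

From the compounds shown here alone, whether an amine or a carboxylic acid in place of these aromatic rings on the same chain carbon would shift the number stays open. Also open, going by these compounds, is whether the sulfonyl step holds with 2-methoxyphenyl in place of 2,4,6-trimethoxyphenyl.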